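The compounds below may be only part of what the source reports. "The series", "measured", "known", "first", "only" and "open" are said of these compounds alone.

Compound 1 `O=C(/C=C/c1ccccc1)c1ccc(OCc2ccccc2)cc1O` is the starting point of this step. In a functional assay on Ca-Ski cells (Homo sapiens) for antiproliferative activity, with a stated time of 48 h (a lower number here means a stronger inhibitor, a higher number a weaker inhibitor), compound 1 gives > 50000 nM, which is a limit of the assay and not a number. Compound 2 `COc1cc(O)c(C(=O)/C=C/c2ccccc2)cc1Br` gives > 50000 nM in this assay, likewise a limit. Both shown values thus sit at the limit of > 50000 nM in this assay, at which 2 of the 2 values shown sit. Compound 3 `CC(=O)Oc1ccc(C(=O)/C=C/c2ccccc2)c(O)c1` differs from compound 1 by acetyl in place of benzyl on an oxygen on an aromatic ring. Among the measured compounds shown here, no measured step of this kind exists, so the expected step that the limit leaves unreadable from compound 1 to compound 3 is estimated to stay within the usual scatter, with no direction assigned. Compound 3 is expected to give 60000 nM, in the range 20000 nM to 200000 nM, most probably again reported only as a limit.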

Compound 3, half-maximal inhibitory concentration: > 50000 nM
Compound 3 gave a limit, no number; the forecaster's own chance of this, stated with the estimate: 80%; the middle value is on the limit's open side.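

Compound 3 gives > 50000 nM in this assay, a limit and not a number. Among the compounds shown here, no step between compound 1 and compound 3 can therefore be read. The compounds shown leave open whether any change on the shared core affects activity, as every value sits at one limit: the limit of > 50000 nM in this assay, at which 3 of the 3 values shown sit.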